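This account rests on a few compounds, and the source may have more. Where it says the series, first, only, none or still open, it means among the compounds named here.

Compound 3 `Cc1ncnc2c1c(-c1ccoc1)cn2[C@@H]1O[C@H](CO)[C@@H](O)[C@H]1O` gives 5320 nM in a functional assay on HepG2 cells (Homo sapiens) for antiproliferative activity, read by XTT assay, with a stated time of 72 h (on this read-out higher numbers stand for weaker inhibition and lower numbers for stronger inhibition), the highest of the three numbers measured. Compound 2 `COc1ncnc2c1c(-c1ccoc1)cn2[C@@H]1O[C@H](CO)[C@@H](O)[C@H]1O` gives 290 nM, and compound 1 `C#Cc1cn([C@@H]2O[C@H](CO)[C@@H](O)[C@H]2O)c2ncnc(N(C)C)c12` gives 1320 nM. Going by the values given here, the single one-place step available, an 18-fold higher number from compound 2 to compound 3 (1.26 log units; beyond the scatter), shows how much a change at this position can move the read-out. Compound 4 `CN(C)c1ncnc2c1c(-c1ccoc1)cn2[C@@H]1O[C@H](CO)[C@@H](O)[C@H]1O` differs from compound 3 by dimethylamino in place of methyl on an aromatic carbon. Among the compounds with values here, no measured step covers dimethylamino against methyl at this place, though compound 1 carries the dimethylamino group on a different core. Given the large step seen from compound 2 to compound 3, a sizeable drop is expected for compound 4, estimated as a 12-fold lower number from compound 3 to compound 4 (1.07 log units; beyond the scatter). Compound 4 is therefore estimated at 450 nM, within 120 nM to 1700 nM.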

Compound 4, half-maximal inhibitory concentration: 12500 nM
Beside the measured number, compound 4's estimate is 28-fold (1.44 log units) below it; measured number outside the range, above it.
By their numbers in this assay, from the lowest: compound 2; then compound 1; then compound 3; then compound 4.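

Replacing methyl with dimethylamino does not lower the number in this assay; it gives a 2.3-fold higher number from compound 3 to compound 4 (0.37 log units; beyond the scatter). Against methoxy, the same group gives a 43-fold higher number from compound 2 to compound 4 (1.63 log units; beyond the scatter), so among these three groups at this place, methoxy alone gives the lowest number. With dimethylamino held fixed, furan-3-yl in place of ethynyl also raises the number, giving a 9.5-fold higher number from compound 1 to compound 4 (0.98 log units; beyond the scatter), and no evidence at hand accounts for these differences.

On these data alone, how an ethoxy group or a primary amine would read at this place remains open, as does whether ethynyl alongside methoxy would change the order.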